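Serum Protein Binding of Two Related Pairs

The source may hold more compounds than are shown below. What is called first, only, known or untested is meant among the compounds shown, and "the series" means these compounds.

Four compounds are compared here. Compound 1 `COc1ccc(C(=O)C2=C(O)C(=O)N(c3ccc(-c4ccon4)cc3)C2c2ccccc2OC)cc1` and compound 2 `COc1ccc(C(=O)C2=C(O)C(=O)N(c3ccc(-c4ccon4)cc3)C2c2ccccc2OCCO)cc1` share one core, while compound 3 `COc1ccccc1C1C(C(=O)C(C)C)=C(O)C(=O)N1c1ccc(-c2ccsc2)cc1` and compound 4 `CC(C)C(=O)C1=C(O)C(=O)N(c2ccc(-c3ccsc3)cc2)C1c1ccccc1OCCO` share another; the difference between the two cores is not broken down here.

The read-out is an ADME assay on the whole organism (serum, Rattus norvegicus) for protein binding; a higher number here means a larger unbound share of the compound, a lower number a smaller unbound share. In this assay compound 1 gives 0.0049, and compound 2 gives 0.003. Compound 3 gives 0.001, the lowest of the three measured numbers, and its gap to each of the others lies beyond the scatter.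

The step within the first pair is hydroxymethyl in place of hydrogen on a saturated chain carbon bound to an oxygen on an aromatic ring, and it made a 1.6-fold lower number from compound 1 to compound 2 (0.21 log units; within the scatter). The change from compound 3 to compound 4 is hydroxymethyl in place of hydrogen on a saturated chain carbon bound to an oxygen on an aromatic ring, the same change, at the same kind of place, only now on the other core.

Because the earlier step of a 1.6-fold lower number from compound 1 to compound 2 (0.21 log units; within the scatter) stayed within the scatter, the expectation for the second pair is a step of about the same size and direction, with compound 4 expected to come out at or slightly under compound 3. The step from compound 3 to compound 4 is estimated at a 1.4-fold lower number from compound 3 to compound 4 (0.15 log units; within the scatter). On that basis compound 4 is expected to give 0.0007, with a likely range from 0.0003 to 0.0015.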

Compound 4, unbound fraction: 0.002
Compound 4: the middle estimate sits 2.9-fold (0.46 log units) below what was measured, and the stated range ends below it.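

In this assay, the change from methoxy to 2-hydroxyethoxy gives a 2.0-fold higher number from compound 3 to compound 4 (0.30 log units; within the scatter). Taken alone, this step is small, as was the earlier step on the other core, but the two point in opposite directions, and the gap between them is larger than the scatter of two such steps: the same change on two cores in this assay, a 1.6-fold lower number (0.21 log units; within the scatter) from compound 1 to compound 2 and a 2.0-fold higher number (0.30 log units; within the scatter) from compound 3 to compound 4, 3.3-fold (0.51 log units) apart, beyond the scatter of two such steps

This shows that, across these two pairs, the step seen on one core did not carry over in size and direction to the other, so the first pair alone was not a safe guide to the second. Going by these compounds alone, it does not show that the change reliably raises the number on one core or lowers it on the other, and with only two pairs it cannot show why the steps differ or what would happen on a third core.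

The compounds shown leave open how an amine, a carboxylic acid or a longer chain ending in a hydroxyl group would behave at this same place on each core. They also leave open which of the structural differences between the two cores goes with the gap between the two steps.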